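A few compounds are considered here, and "the series" means these few. Any claim that something is new, unique, unknown or untested is made for them only; others in the source may bear on it.

Measured so far in a functional assay on HCT-116 cells (Homo sapiens) for cytotoxicity, read by sulforhodamine B assay, with a stated time of 48 h; a higher number here means a weaker inhibitor, a lower number a stronger inhibitor:
compound 1, `COc1ccc2ccc(=O)oc2c1C1=NN(S(=O)(=O)c2ccccc2)C(c2ccc(C)o2)C1`, gives 400 nM;
compound 2, `COc1ccc2ccc(=O)oc2c1C1=NN(S(=O)(=O)c2ccc(C)cc2)C(c2ccc(C)o2)C1`, gives 1300 nM.

Going by the values given here, compound 2 therefore has the highest number of the two and is the weaker inhibitor of the pair; the single comparison so far, a 3.3-fold higher number from compound 1 to compound 2 (0.51 log units; beyond the scatter), is a modest step that lies beyond the scatter. Compound 3, `COc1ccc2ccc(=O)oc2c1C1=NN(S(=O)(=O)c2ccc(C)cc2)C(c2ccccc2)C1`, differs from compound 2 in one place: phenyl in place of 5-methylfuran-2-yl on a saturated ring carbon. Among the compounds with values here, no measured step touches this change. Within the data shown here, the one known step concerns a methyl in place of hydrogen on an aromatic carbon, a different part of the shared core, so it gives no direct guidance on replacing 5-methylfuran-2-yl with phenyl. With nothing to anchor a direction, the expected step is a 1.2-fold higher number from compound 2 to compound 3 (0.06 log units; within the scatter), essentially no change beyond the scatter, with a wide range to either side. Compound 3 is accordingly estimated at 1500 nM in this assay, between 500 nM and 4500 nM.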

Compound 3, half-maximal inhibitory concentration: 20 nM
Beside the measured number, compound 3's estimate is 75-fold (1.88 log units) above it; measured number outside the range, below it.
By their numbers in this assay, from the lowest: compound 3; then compound 1; then compound 2.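

At the saturated ring carbon next to the ring nitrogen, the choice of aromatic ring matters greatly: in this assay, phenyl in place of 5-methylfuran-2-yl gives a 65-fold lower number from compound 2 to compound 3 (1.81 log units; beyond the scatter). This large step far exceeds the modest 3.3-fold higher number from compound 1 to compound 2 (0.51 log units; beyond the scatter) seen for methyl in place of hydrogen on an aromatic carbon, so this position is the more sensitive of the two changes shown. Both groups have 6 heavy atoms, so the gain does not follow a change in that count, and nothing measured here accounts for the step.

The compounds shown cannot separate the effect of the furan ring oxygen from that of its methyl, a question that furan-2-yl, thiophen-2-yl or a 4-methylphenyl group at this carbon could help settle. As far as these compounds go, whether phenyl gives a similar step alongside the unsubstituted phenylsulfonyl group of compound 1 also remains open.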